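This account rests on a few compounds, and the source may have more. Where it says the series, first, only, none or still open, it means among the compounds named here.

Measured compounds:
Compound 1 `O=[N+]([O-])c1cc(S(=O)(=O)Nc2ccc(-c3nc4ccccc4o3)cc2)ccc1Cl` gives 17000 nM in an assay on cells for inhibition of HSP60/HSP10 (Homo sapiens), with a stated time of 60 min; on this read-out higher numbers stand for weaker inhibition and lower numbers for stronger inhibition.
Compound 2 `COc1cccc(S(=O)(=O)Nc2ccc(-c3nc4ccccc4o3)cc2)c1` gives 80000 nM in this assay.

Of the two numbers recorded, compound 2 stands highest, which on this read-out means the weakest inhibition of the pair; compound 1 lies a good way below it, and that gap is beyond the usual scatter. Compound 3 `O=S(=O)(Nc1ccc(-c2nc3ccccc3o2)cc1)c1ccc(Cl)c(Cl)c1` has not yet been measured. It differs from compound 2 in a single place: 3,4-dichlorophenyl in place of 3-methoxyphenyl on a sulfonyl sulfur. Among the compounds with values here, no pair of measured compounds shows this particular exchange, so its effect cannot be read off directly; the only guide is that compound 1, with a different substituted aryl group on the same sulfonyl sulfur, gives 17000 nM. On that basis a moderate move toward stronger inhibition is expected, roughly a 4.0-fold lower number from compound 2 to compound 3 (0.60 log units; beyond the scatter). The estimated value for compound 3 in this assay is 20000 nM, with a range from 7000 nM to 60000 nM.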

Compound 3, half-maximal inhibitory concentration: 25000 nM
Estimate against measurement, compound 3: 1.3-fold (0.10 log units) below, and the stated range covers the measured number.
By their numbers in this assay, from the lowest: compounds 1 and 3 (each within the scatter of the next); then compound 2.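

The exchange of 3-methoxyphenyl for 3,4-dichlorophenyl on the sulfonyl sulfur can now be read directly in this assay: it gives a 3.2-fold lower number from compound 2 to compound 3 (0.51 log units; beyond the scatter) as a modest step beyond the usual scatter. Chloro in place of nitro on an aromatic carbon gives a 1.5-fold higher number from compound 1 to compound 3 (0.17 log units; within the scatter) and lies within the scatter, so this read-out does not separate those two groups at that place. Nothing measured here explains either step.

As far as these compounds go, it remains open how an amine or a carboxylic acid on this aryl ring would change the inhibition, or whether a simple alkyl chain in place of the ring on the sulfonyl sulfur would keep it. From the compounds shown here alone, all three compounds share the rest of their structure, so the effect of changes elsewhere in the core also remains unknown.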